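The source may hold more compounds than are shown below. What is called first, only, known or untested is meant among the compounds shown, and "the series" means these compounds.

Compound 3 `Cn1c(/C=C2\SC(=O)N(CC(=O)N3CCCCC3)C2=O)nc2ccccc21` carries a methyl on an aromatic nitrogen and a piperidin-1-yl on a carbonyl carbon. In a functional assay on PC-3 cells (Homo sapiens) for inhibition, read by MTT assay, with a stated time of 48 h (a higher number here means a weaker inhibitor, a lower number a stronger inhibitor), compound 3 gives no number but only a limit, > 50000 nM. Compound 1 `CC(C)n1c(/C=C2\SC(=O)N(CC(=O)N3CCCCC3)C2=O)nc2ccccc21` has an isopropyl on that nitrogen instead; in this assay compound 1 likewise reaches only a limit, > 50000 nM. Compound 2 `Cn1c(/C=C2\SC(=O)N(CC(=O)N3CCOCC3)C2=O)nc2ccccc21` has morpholin-4-yl on the carbonyl carbon instead; in this assay compound 2 also gives only a limit, > 50000 nM. Two steps lead to compound 3, a step that the two limits leave unreadable from compound 1 to compound 3 and a step that the two limits leave unreadable from compound 2 to compound 3, and neither has a readable size because of the limit of > 50000 nM in this assay, at which 3 of the 3 values shown sit. So compound 3 stands where every compound here stands: at the limit, with no measured step to lean on.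

Compound 4 `CCn1c(/C=C2\SC(=O)N(CC(=O)N3CCCCC3)C2=O)nc2ccccc21` differs from compound 3 by methyl in place of hydrogen on a saturated chain carbon bound to an aromatic nitrogen. The step from compound 1 to compound 3 touched the same aromatic nitrogen substituent and stayed at the limit, so nothing here points to a change in either direction. Compound 4 is therefore expected to remain at the limit, with an estimated step of a number no higher from compound 3 to compound 4 (the limit leaves the size open) from compound 3. The estimate for compound 4 is 50000 nM, ranging from 15000 nM to 200000 nM.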

Compound 4, half-maximal inhibitory concentration: > 50000 nM
Compound 4 ended at the assay's limit; the forecaster's own chance of this, stated with the estimate: 85%; the middle value lies on the limit itself.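

The steps joining compound 4 to compound 3 and to compound 1 cannot be read, because these results are limits and not numbers: the limit of > 50000 nM in this assay, at which 4 of the 4 values shown sit. The compounds shown leave open how strongly any of them acts in this assay, since none yet gives a value inside the limit.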